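Acetyl to Furan-2-yl Carbonyl on a Shared Core

The compounds below may be only part of what the source reports. "The series", "measured", "known", "first", "only" and "open" are said of these compounds alone.

Compound 1 `CC(C)CCn1c(OC2CCN(C(=O)c3ccco3)CC2)nc2ccccc21`: 30.8%
Compound 2 `CC(=O)N1CCN(Cc2nc3ccccc3n2Cc2cccc(C)c2)CC1`: 70.3%

Both compounds were tested in an assay on isolated protein for inhibition of aldehyde dehydrogenase 1A1 (Homo sapiens), read by spectrophotometry, tested at 10 uM; on this read-out higher numbers stand for more inhibition at the one concentration tested (going by the name of the read-out) and lower numbers for less inhibition. Compound 2 gives 70.3%, the higher of the two numbers, while compound 1 gives 30.8%, a gap that lies beyond the usual scatter. Compound 3 `Cc1cccc(Cn2c(CN3CCN(C(=O)c4ccco4)CC3)nc3ccccc32)c1` has not yet been measured. It differs from compound 2 in a single place: furan-2-yl in place of methyl on a carbonyl carbon. Cut one bond further out, the change reads acetyl to (furan-2-yl)carbonyl. For the measured compounds named here, no measured pair isolates this change, since compound 1 differs from compound 2 in several places at once, so the step from compound 2 to compound 3 can only be guessed. The step of a number 5.3 percentage points lower from compound 2 to compound 3 (within the scatter) is expected to be small and inside the scatter. Because compound 2 gives 70.3% in this assay , compound 3 is expected to give about 65%, in a range from 40% to 85%.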

Compound 3, a percentage reported as inhibition, at one concentration (the size of the read-out at that concentration, not a potency): 73.2%
Compound 3: middle estimate off by 8.2 percentage points, on the low side, and the stated range covers the measured number.
By their numbers in this assay, from the lowest: compound 1; then compounds 2 and 3 (each within the scatter of the next).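

In this assay, putting furan-2-yl in place of methyl on the carbonyl carbon gives a number 2.9 percentage points higher from compound 2 to compound 3 (within the scatter), so the two compounds cannot be told apart. This place, a carbonyl carbon bound to an amide-type nitrogen in a ring, therefore holds a five-membered aromatic ring as well as a methyl, with no difference beyond the scatter at the one concentration tested. Nothing measured here bears on why the two groups read alike.

The compounds shown leave open how other groups would read at this carbonyl carbon, such as a phenyl ring, a longer chain like butyl, or an amine. Also open, on these data alone, is whether a reading at one concentration conceals a difference in potency between compound 2 and compound 3.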